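A Second Methoxy Group on the Aryl Propanamide Side Chain

The source may report more compounds than this note shows. Statements on the series, on what has been measured and on what is new or still open speak of the compounds shown alone.

Compound 1, `CCC(C)[C@H](N)c1cc(C(F)(F)F)ccc1N1CCN(C(=O)CCc2ccc(Cl)cc2)CC1`, gives 86 nM in an assay on HEK293 cells for displacement of a labelled ligand from Melanocortin receptor 4 (Homo sapiens); a higher number here means a weaker inhibitor, a lower number a stronger inhibitor.
Compound 2, `COc1cccc(CCC(=O)N2CCN(c3ccc(C(F)(F)F)cc3[C@@H](N)CC(C)C)CC2)c1`, gives 4000 nM.

Compound 2 thus carries the highest of the two numbers, and compound 1 lies well below it, a gap beyond the scatter. Compound 3, `COc1ccc(OC)c(CCC(=O)N2CCN(c3ccc(C(F)(F)F)cc3[C@@H](N)CC(C)C)CC2)c1`, differs from compound 2 by methoxy in place of hydrogen on an aromatic carbon. Within the data shown here, no pair of measured compounds shows this change, so its effect is unknown. For compound 3 a small shift in this assay is expected, possibly none beyond the scatter. Compound 3 is estimated at 3000 nM, between 800 nM and 10000 nM. The expected step is a 1.3-fold lower number from compound 2 to compound 3 (0.12 log units; within the scatter).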

Compound 3, inhibition constant: 2500 nM
For compound 3 the middle estimate is 1.2-fold (0.08 log units) above the measured one; low and high end bracket the measured number.
By their numbers in this assay, from the lowest: compound 1; then compounds 3 and 2 (each within the scatter of the next).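

Placing a methoxy group on this aromatic carbon, ortho to a large group and para to a methoxy group, turns 3-methoxyphenyl into 2,5-dimethoxyphenyl. In this assay the change gives a 1.6-fold lower number from compound 2 to compound 3 (0.20 log units; within the scatter) and so shows that this position accepts a second methoxy group with no shift that can be told from the scatter. Nothing measured here offers an explanation for this result.

On these data alone, whether a hydroxy group, an amine or a carboxylic acid on this same carbon would leave the number equally unmoved remains open.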